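Diethylsulfamoyl for Methoxycarbonyl: Expecting No Cytotoxic Signal

The compounds below may be only part of what the source reports. "The series", "measured", "known", "first", "only" and "open" are said of these compounds alone.

Compound 1 `COC(=O)c1cccc(C(=O)N2CCCC(C(=O)Nc3ccc(Cl)cc3)C2)c1` gives 0% in an ADME assay on PC-3 cells (Homo sapiens) for cytotoxicity, read by WST assay, tested at 100 uM; a higher number here means more inhibition at the concentration tested (going by the name of the read-out), a lower number less inhibition. The two other measured compounds sit close by: compound 2 `O=C(Nc1cccc(Oc2ccccc2)c1)C1CCCN(C(=O)c2cc(C(F)(F)F)cc(C(F)(F)F)c2)C1` gives 1%, and compound 3 `COc1cccc(NC(=O)C2CCCN(C(=O)c3cc(C(F)(F)F)cc(C(F)(F)F)c3)C2)c1` gives 0%. Compound 1 is therefore level with compound 3 at the digits shown, the two together the lowest of the three numbers, and it lies nearest to compound 3 with no change at those digits, while compound 2 is the furthest, higher by a margin that is still within the scatter. Among the measured compounds shown here, the one step that can be read from these compounds, methyl in place of phenyl on an oxygen on an aromatic ring, is a number 1 percentage points lower from compound 2 to compound 3 (within the scatter), within the scatter.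

Compound 4 `CCN(CC)S(=O)(=O)c1cccc(C(=O)N2CCCC(C(=O)Nc3ccc(Cl)cc3)C2)c1` differs from compound 1 in one place: diethylsulfamoyl in place of methoxycarbonyl on an aromatic carbon. For the measured compounds named here, no measured step alters this part of the shared core, and the only measured step at all is within the scatter, so the expected step is a number 2 percentage points higher from compound 1 to compound 4 (within the scatter), none beyond the scatter. Compound 4 is therefore estimated at 2%, in the range 0% to 15%.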

Compound 4, a percentage reported as inhibition, at one concentration (the size of the read-out at that concentration, not a potency): 0%
Compound 4: the middle estimate sits 2 percentage points above what was measured; the measured number falls inside the stated range.
By their numbers in this assay, from the lowest: compounds 1, 3, 4 and 2 (each within the scatter of the next).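

Among the compounds shown here, putting diethylsulfamoyl in place of methoxycarbonyl on this aromatic carbon gives no change at the digits printed from compound 1 to compound 4 (within the scatter) in this assay and is the first reading at this position of the shared core. The group that enters holds 8 heavy atoms against 4 for the one that leaves and brings in a sulfur and a nitrogen, yet the read-out does not separate the two compounds. Nothing shown explains why the number stays where it is.

From the compounds shown here alone, all the compounds shown sit together at the bottom of the scale, so it remains open whether any change at this position can raise inhibition at all. A carboxylic acid, a primary amine or a longer alkyl chain on this aromatic carbon could test that, and the present data do not say how any of them would read.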